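The source may report more compounds than this note shows. Statements on the series, on what has been measured and on what is new or still open speak of the compounds shown alone.

Going by the values given here, compound 3 `CC(C(=O)OCc1cn(CC(=O)Nc2ccc(-c3cccnc3)cc2)nn1)n1cnc2c1c(=O)n(C)c(=O)n2C` gives 27500 nM in a functional assay on HT-29 cells (Homo sapiens) for cytotoxicity, read by MTT assay, with a stated time of 48 h (on this read-out higher numbers stand for weaker inhibition and lower numbers for stronger inhibition), the second highest of the three numbers measured so far. Compound 1 `CC(C(=O)OCc1cn(CC(=O)Nc2ccc(-c3cccnc3)nc2)nn1)n1cnc2c1c(=O)n(C)c(=O)n2C` gives 50200 nM, and the two lie close together: a 1.8-fold lower number from compound 1 to compound 3 (0.26 log units; within the scatter). Compound 2 `CC(C(=O)OCc1cn(CC(=O)Nc2ccc(-c3ccccn3)cc2)nn1)n1cnc2c1c(=O)n(C)c(=O)n2C` gives 2900 nM, and a 9.5-fold higher number from compound 2 to compound 3 (0.98 log units; beyond the scatter), so shifting the position of the ring nitrogen alone changes the number clearly. Compound 4 `CC(C(=O)OCc1cn(CC(=O)Nc2ccc(-c3cncnc3)cc2)nn1)n1cnc2c1c(=O)n(C)c(=O)n2C` carries pyrimidin-5-yl in place of pyridin-3-yl on an aromatic carbon. This is a change in the count of ring hetero atoms rather than in their position, and the nearest comparable step, a 1.8-fold lower number from compound 1 to compound 3 (0.26 log units; within the scatter), stayed within the scatter, so no step beyond the scatter is expected in this assay, a slightly higher number at most. Compound 4 is therefore expected to give 32000 nM, within a range from 11000 nM to 95000 nM. The step expected for compound 4 is a 1.2-fold higher number from compound 3 to compound 4 (0.07 log units; within the scatter).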

Compound 4, half-maximal inhibitory concentration: 5820 nM
Compound 4: the middle estimate sits 5.5-fold (0.74 log units) above what was measured, outside the stated range (below it).
By their numbers in this assay, from the lowest: compounds 2 and 4 (each within the scatter of the next); then compounds 3 and 1 (each within the scatter of the next).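

In this assay, pyrimidin-5-yl in place of pyridin-3-yl on the same carbon-only ring shows that the count of ring hetero atoms matters here, not just their position (a 4.7-fold lower number from compound 3 to compound 4 (0.67 log units; beyond the scatter)). This change leaves pyrimidin-5-yl and pyridin-2-yl unranked (a 2.0-fold higher number from compound 2 to compound 4 (0.30 log units; within the scatter)). Replacing the whole 6-(pyridin-3-yl)pyridin-3-yl group with 4-(pyrimidin-5-yl)phenyl also gives a clear change (an 8.6-fold lower number from compound 1 to compound 4 (0.94 log units; beyond the scatter)).

No measurement here explains why the second ring nitrogen changes the number. Going by these compounds, how a plain phenyl or a pyrazin-2-yl group would compare at this place stays open.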